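Lengthening the Chain and Branching at the Amine

This account rests on a few compounds, and the source may have more. Where it says the series, first, only, none or still open, it means among the compounds named here.

The study concerns a small set of compounds that share an amine nitrogen and an oxygen on a saturated carbon along a long saturated chain. Compound 1, `CCCCCCCCC[C@@H](O)[C@H](C)N`, serves as the reference point. In a functional assay on HeLa cells (Homo sapiens) for antiproliferative activity, read by sulforhodamine B assay, with a stated time of 48 h (on this read-out higher numbers stand for weaker inhibition of growth and lower numbers for stronger inhibition of growth), compound 1 gives 9200 nM. Compound 2, `CCCCCCCCC[C@@H](O)[C@@H](N)[C@@H](C)CC`, differs from it in one place: sec-butyl in place of methyl on a saturated chain carbon bound to an amine nitrogen and a saturated chain carbon. In this assay compound 2 gives 20000 nM, and the step reads a 2.2-fold higher number from compound 1 to compound 2 (0.34 log units; beyond the scatter). Compound 3, `CCCCCCCCCCCCCCC[C@@H](O)[C@H](C)N`, differs from compound 1 at the far end of the chain: hexyl in place of hydrogen on a saturated chain carbon, ten or more bonds along the chain from an oxygen on a saturated carbon. In this assay compound 3 gives 2600 nM, the lowest of the three measured numbers, and the step from compound 1 reads a 3.5-fold lower number from compound 1 to compound 3 (0.55 log units; beyond the scatter). For the measured compounds named here, no step between compound 2 and compound 3 is broken down here; their two values simply stand apart.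

Compound 4, `CCCCCCCCCCCCCCC[C@@H](O)[C@@H](N)[C@@H](C)CC`, has not yet been measured. It stands to compound 3 as compound 2 stands to compound 1: sec-butyl in place of methyl on a saturated chain carbon bound to an amine nitrogen and a saturated chain carbon. The place of the change is described in the same words for both pairs, so it is the same change, occurring twice in the set. The two cores differ as given by hexyl in place of hydrogen on a saturated chain carbon, ten or more bonds along the chain from an oxygen on a saturated carbon. Compound 4 is expected to show a step of a 2.2-fold higher number from compound 3 to compound 4 (0.34 log units; beyond the scatter), because a 2.2-fold higher number from compound 1 to compound 2 (0.34 log units; beyond the scatter) was recorded for the same change on the shorter core, though this rests on a single earlier instance. Compound 4 is therefore estimated to give about 5700 nM in this assay, with an expected range from 2600 nM to 13000 nM.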

Compound 4, concentration for 50% growth inhibition: 20000 nM
Compound 4: the middle estimate sits 3.5-fold (0.55 log units) below what was measured; measured number above the stated range.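

Replacing methyl with sec-butyl gave a 7.7-fold higher number from compound 3 to compound 4 (0.89 log units; beyond the scatter) in this assay, so the size of the step seen on the core of compound 1 did not carry over to the core of compound 3: the same change on two cores in this assay, a 2.2-fold higher number (0.34 log units; beyond the scatter) from compound 1 to compound 2 and a 7.7-fold higher number (0.89 log units; beyond the scatter) from compound 3 to compound 4, 3.5-fold (0.55 log units) apart, beyond the scatter of two such steps. The hexyl change did not carry over either, since on the sec-butyl compounds it gave no change at the digits printed from compound 2 to compound 4 (within the scatter), unlike its earlier step on the methyl compounds: the same change on two cores in this assay, a 3.5-fold lower number (0.55 log units; beyond the scatter) from compound 1 to compound 3 and no change at the digits printed (within the scatter) from compound 2 to compound 4, 3.5-fold (0.55 log units) apart, beyond the scatter of two such steps. The sec-butyl compound has the higher number in both pairs, so the direction of that change held on these two cores, but two pairs cannot explain the difference in size or show how the change would behave on any further core.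

The compounds shown leave open whether a shorter chain or a longer chain would follow the same course with either methyl or sec-butyl at this place. They also leave open what an isopropyl group or a phenyl group in place of methyl, or an acetamide in place of the amine, would give in this assay.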